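Replacing trifluoromethyl in compound 2 with hydrogen: working notes

This account rests on a few compounds, and the source may have more. Where it says the series, first, only, none or still open, it means among the compounds named here.

In a functional assay on the whole organism (Cavia porcellus) with Rattus norvegicus as the target (on this read-out lower numbers stand for an effect already at smaller amounts and higher numbers for an effect only at larger amounts of compound), compound 1 `CC1=CS[C@@](O)(c2ccc([N+](=O)[O-])cc2)c2noc(=O)n21` gives 607000000 nM and compound 2 `CC1=CS[C@@](O)(c2cccc(C(F)(F)F)c2)c2noc(=O)n21` gives 461000000 nM as its reading. Among the measured compounds shown here, these are the only two measurements so far. They lie within the scatter of each other, so compound 2 stands level with compound 1 and the pair sets no order.

The next compound, compound 3 `CC1=CS[C@@](O)(c2ccccc2)c2noc(=O)n21`, keeps the shared core and differs from compound 2 at one place (hydrogen in place of trifluoromethyl on an aromatic carbon; (hydrogen in place of trifluoromethyl on an aromatic carbon)). For the measured compounds named here, no measured compound yet lacks a group on that aromatic ring, so this change has no direct precedent in the data. Going by the values given here, the only guide is that compound 1 at 607000000 nM and compound 2 at 461000000 nM show no gap beyond the scatter.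

No shift beyond the scatter is expected in either direction, and the estimated change is a 1.1-fold higher number from compound 2 to compound 3 (0.04 log units; within the scatter) in this assay, which remains within it. For compound 3 an estimated 500000000 nM is expected, with a range from 200000000 nM to 1200000000 nM around it.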

Compound 3, half-maximal effective concentration: 152000000 nM
Beside the measured number, compound 3's estimate is 3.3-fold (0.52 log units) above it; measured number outside the range, below it.
By their numbers in this assay, from the lowest: compound 3; then compounds 2 and 1 (each within the scatter of the next).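

In this assay, hydrogen on this aromatic ring gives the first gap beyond the scatter in the series, with a 3.0-fold lower number from compound 2 to compound 3 (0.48 log units; beyond the scatter) on loss of trifluoromethyl and a 4.0-fold lower number from compound 1 to compound 3 (0.60 log units; beyond the scatter) on loss of nitro. Both steps are modest and run the same way: among these three compounds, each of the two groups goes with a higher number than hydrogen, and no compound shown goes against this, so the ring without a group now marks the low end of the series. Nothing measured on these compounds bears on why the number falls when either group leaves.

Still open, on these data alone, is whether any group on this aromatic ring can match or pass hydrogen, since only trifluoromethyl and nitro stand against it here, and an amine, a carboxylic acid or a methoxy group would test whether the higher number holds beyond those two. The compounds shown also leave open how far the result depends on where a group sits on the ring, as no single group appears at more than one place.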